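This account rests on a few compounds, and the source may have more. Where it says the series, first, only, none or still open, it means among the compounds named here.

Three compounds that share one core differ only in the group attached to the carbonyl carbon of a carbamate-like unit. Compound 1 `Cc1nc(S(C)(=O)=O)ccc1Oc1ncnc(OC2CCN(C(=O)OC(C)C)CC2)c1F` carries an isopropoxy group there and in a functional assay on isolated protein for inhibition of Glucose-dependent insulinotropic receptor (Rattus norvegicus), read by HTRF and cAMP accumulation (a lower number here means a smaller maximal response, a higher number a larger maximal response), compound 1 gives 77%. Compound 2 `Cc1nc(S(C)(=O)=O)ccc1Oc1ncnc(OC2CCN(C(=O)O[C@@H](C)C(F)(F)F)CC2)c1F` carries a 1-(trifluoromethyl)ethoxy group and gives 80%. Compound 3 `Cc1nc(S(C)(=O)=O)ccc1Oc1ncnc(OC2CCN(C(=O)SC(C)C)CC2)c1F` carries an isopropylsulfanyl group and gives 81%. All three numbers lie close together: a number 3 percentage points higher from compound 1 to compound 2 (within the scatter), a number 4 percentage points higher from compound 1 to compound 3 (within the scatter) and a number 1 percentage points higher from compound 2 to compound 3 (within the scatter), so compound 3 sits among values that the other two match within the usual scatter.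

Compound 4 `Cc1nc(S(C)(=O)=O)ccc1Oc1ncnc(OC2CCN(C(=O)SC3(C)CC3)CC2)c1F` is made from compound 3 by a single change: 1-methylcyclopropyl in place of isopropyl on a sulfur. Among the compounds with values here, no measured step touches the group on the sulfur itself; the closest comparisons are the exchange of the oxygen-bound alkyl in the step from compound 1 to compound 2 and the exchange of oxygen for sulfur in the steps to compound 3, and every one of these stayed within the scatter. A shift beyond the scatter in this assay is therefore not expected in either direction, and the step is estimated as a number 1 percentage points lower from compound 3 to compound 4 (within the scatter). Compound 4 is expected to give 80%, most likely between 70% and 90%.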

Compound 4, largest response reached (reported as efficacy), in percent of the reference or control that the assay uses: 77%
Estimate against measurement, compound 4: 3 percentage points above; low and high end bracket the measured number.
By their numbers in this assay, from the lowest: compounds 1, 4, 2 and 3 (each within the scatter of the next).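

Within the data shown here, compound 4 is the first compound here in which the group on the sulfur itself is exchanged, and in this assay putting 1-methylcyclopropyl in place of isopropyl, which brings in a three-membered ring of carbon, gives a number 4 percentage points lower from compound 3 to compound 4 (within the scatter) and so no readable shift. The comparisons with the two oxygen-linked groups agree, with a number 3 percentage points lower from compound 2 to compound 4 (within the scatter) and with no change at the digits printed from compound 1 to compound 4 (within the scatter), so all four groups on the carbonyl carbon now give maximal responses that match within the usual scatter, and this holds with or without the ring. Nothing measured here offers an explanation for these numbers.

Still open, going by these compounds, is how a longer chain such as n-hexyl on the sulfur, a phenyl ring in the same place, or an amine on the carbonyl carbon, which would turn the unit into a urea, would read in this assay and whether the close match would survive. Equally open, on these data alone, is whether these four compounds also match in any read-out other than the largest response reached.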